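The source may report more compounds than this note shows. Statements on the series, on what has been measured and on what is new or still open speak of the compounds shown alone.

In a functional assay on the whole organism with Mus musculus as the target (on this read-out higher numbers stand for an effect only at larger amounts of compound and lower numbers for an effect already at smaller amounts), compound 1 `CNC(=O)/C(C)=C/c1cccc(C(F)(F)F)c1` gives only a limit, > 100 mg/kg. Compound 2 `O=C1CCC(O)(c2cccc(C(F)(F)F)c2)N1` also gives only a limit, > 200 mg/kg, and this is all that is known of where it stands. Compound 3 `CCCCN1C(=O)CCC1(O)c1cccc(C(F)(F)F)c1` carries butyl in place of hydrogen on an amide-type nitrogen in a ring. Within the data shown here, no measured pair shows the effect of such a change, so only a cautious guess is possible: a moderate shift towards a smaller effective dose. The expected change is an at least 1.6-fold lower number from compound 2 to compound 3 (0.22 log units; that floor lies within the scatter). For compound 3 the estimated dose is 120 mg/kg, with an expected range of 50 mg/kg to 300 mg/kg.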

Compound 3, dose for half-maximal effect: > 200 mg/kg
Compound 3 ended at the assay's limit; the forecaster's own chance of this, stated with the estimate: 50%; at least 1.6-fold (0.22 log units) between middle value and limit.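

In this assay, compound 2 and compound 3 each give only a limit, not a number, and the step between them cannot be read. The compounds shown leave open whether butyl in place of hydrogen changes the effective dose at all.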